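Ring-nitrogen aryl variation on the shared core

This account rests on a few compounds, and the source may have more. Where it says the series, first, only, none or still open, it means among the compounds named here.

Compound 3 `CCOc1ccccc1-n1nncc1CN1C(=O)C2(C(C#N)=C(N)Oc3c(N)cc4nc5ccccc5nc4c32)c2ccccc21` sits at a limit of a functional assay on HCT-116 cells (Homo sapiens) for antiproliferative activity, read by MTT assay, with a stated time of 48 h (on this read-out lower numbers stand for stronger inhibition and higher numbers for weaker inhibition), returning > 50000 nM. Its position is therefore known only as far as the limit of > 50000 nM in this assay, at which 2 of the 3 values shown sit. Compound 2 `CCc1ccccc1-n1nncc1CN1C(=O)C2(C(C#N)=C(N)Oc3c(N)cc4nc5ccccc5nc4c32)c2ccccc21` gives 10300 nM in this assay. Compound 1 `Cc1cccc(-n2nncc2CN2C(=O)C3(C(C#N)=C(N)Oc4c(N)cc5nc6ccccc6nc5c43)c3ccccc32)c1` also stops at a limit in this assay, > 50000 nM.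

Of the measured steps, an at least 4.8-fold higher number from compound 2 to compound 3 (0.68 log units; beyond the scatter) bears directly on the group varied here; an at least 4.8-fold lower number from compound 1 to compound 2 (0.68 log units; beyond the scatter) runs in the same sense; a step that the two limits leave unreadable from compound 1 to compound 3.

The unmeasured compound is compound 4 `CCc1cccc(CC)c1-n1nncc1CN1C(=O)C2(C(C#N)=C(N)Oc3c(N)cc4nc5ccccc5nc4c32)c2ccccc21`. The change is 2,6-diethylphenyl in place of 2-ethoxyphenyl on an aromatic nitrogen. Read backwards, the step between compound 2 and compound 3 shows that an ethyl at the first ring position brings the number down to that of compound 2; the second ethyl has no measured precedent in the series, so it is taken as roughly neutral. Compound 4 is thus expected near compound 2, at an estimated 15000 nM (range 4000 nM to 60000 nM). The estimated step is expected as an at least 3.3-fold lower number from compound 3 to compound 4 (0.52 log units; beyond the scatter).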

Compound 4, half-maximal inhibitory concentration: 37600 nM
Compound 4: the middle estimate sits 2.5-fold (0.40 log units) below what was measured, and the stated range covers the measured number.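

The added ethyl of 2,6-diethylphenyl is not silent on this ring in this assay: a 3.7-fold higher number from compound 2 to compound 4 (0.56 log units; beyond the scatter). The steps of an at least 1.3-fold lower number from compound 3 to compound 4 (0.12 log units; that floor lies within the scatter) and an at least 1.3-fold lower number from compound 1 to compound 4 (0.12 log units; that floor lies within the scatter) have floors within the scatter, so they establish no real gain for 2,6-diethylphenyl over 2-ethoxyphenyl or 3-methylphenyl. Compound 1 and compound 3 each stop at a limit, and these two steps are floors only because of that limit: the limit of > 50000 nM in this assay, at which 2 of the 4 values shown sit.

On these data alone, the true positions of compound 1 and compound 3 remain unknown, so the size of any gain in compound 4 over either stays open. Also open, as far as these compounds go, is how a propyl chain, a methoxy group or an amine on the same phenyl ring would compare with the ethyl of compound 2.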